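Nonyl to Sulfonamide on the Triazole Chain

The source may report more compounds than this note shows. Statements on the series, on what has been measured and on what is new or still open speak of the compounds shown alone.

Compound 1 `O=C1O[C@H]([C@@H](O)Cn2cc(-c3ccc(Br)cc3)nn2)C(OCc2ccccc2)=C1OCc1ccccc1` — 3910 nM
Compound 2 `CCCCCCCCCCc1cn(C[C@H](O)[C@H]2OC(=O)C(OCc3ccccc3)=C2OCc2ccccc2)nn1` — 22900 nM

In a functional assay on HeLa cells (Homo sapiens) for antiproliferative activity, read by MTT assay, with a stated time of 72 h (a lower number here means a stronger inhibitor, a higher number a weaker inhibitor), compound 2 gives the higher of the two numbers, compound 1 the lower. The measured step between them, a 5.9-fold higher number from compound 1 to compound 2 (0.77 log units; beyond the scatter), is the only one to draw on. Compound 3 `O=C1O[C@H]([C@@H](O)Cn2cc(CNS(=O)(=O)c3ccc(Cl)cc3F)nn2)C(OCc2ccccc2)=C1OCc1ccccc1` arises from compound 2 by ((4-chloro-2-fluorophenyl)sulfonyl)amino in place of nonyl on a saturated chain carbon bound to an aromatic carbon. That step removes most of the chain and brings in an aromatic ring, a change in the opposite sense to the measured step, so a lower number is expected for compound 3 in this assay, a step of about a 3.8-fold lower number from compound 2 to compound 3 (0.58 log units; beyond the scatter). Compound 3 is therefore estimated at 6000 nM, in the range 1800 nM to 20000 nM.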

Compound 3, half-maximal inhibitory concentration: 20700 nM
Compound 3: the middle estimate sits 3.5-fold (0.54 log units) below what was measured, and the stated range ends below it.
By their numbers in this assay, from the lowest: compound 1; then compounds 3 and 2 (each within the scatter of the next).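

In this assay, the step of a 1.1-fold lower number from compound 2 to compound 3 (0.04 log units; within the scatter) shows that ((4-chloro-2-fluorophenyl)sulfonyl)amino and nonyl are not told apart at this position, on a saturated chain carbon bound to an aromatic carbon. Exchanging a ringless carbon chain for a group with an aromatic ring, a hydrogen-bond donor and hydrogen-bond acceptors thus leaves the reading within the scatter. No measurement at hand offers a reason for this match.

Still open, as far as these compounds go, is how an amine or a carboxylic acid would read on this same chain carbon. So is whether a phenylsulfonyl group without chlorine and fluorine would match compound 3.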